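Lengthening the para chain: from methyl toward undecyl

This account rests on a few compounds, and the source may have more. Where it says the series, first, only, none or still open, it means among the compounds named here.

Two ureas sharing one core have been measured in an assay on isolated protein for inhibition of acyl-CoA:cholesterol acyltransferase (Oryctolagus cuniculus); a lower number here means a stronger inhibitor, a higher number a weaker inhibitor. Compound 1, `CCCCCCCCCCCCCCc1ccc(NC(=O)Nc2c(C(C)C)cccc2C(C)C)cc1`, carries a long tetradecyl chain on the outer ring and gives 500 nM in this assay. Compound 2, `Cc1ccc(NC(=O)Nc2c(C(C)C)cccc2C(C)C)cc1`, carries only a methyl at the same spot and gives 250 nM in this assay. Of the two numbers shown, compound 2 holds the lower end of the pair, yet the gap to compound 1 falls within the usual scatter of repeated measurements, so the two readings cannot be told apart with confidence.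

Compound 3, `CCCCCCCCCCCc1ccc(NC(=O)Nc2c(C(C)C)cccc2C(C)C)cc1`, sits between these two in chain length. Compared with compound 2 the change is decyl in place of hydrogen on a saturated chain carbon bound to an aromatic carbon. Among the compounds with values here, no measured pair maps this step directly, but the two endpoints already known, compound 2 with 250 nM and compound 1 with 500 nM, bracket only a modest spread. The step from the methyl of compound 2 to the undecyl of compound 3 is therefore expected to be small, not beyond the scatter in either direction. Compound 3 is estimated at 350 nM, with a range from 150 nM to 900 nM, an expected change of a 1.4-fold higher number from compound 2 to compound 3 (0.15 log units; within the scatter).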

Compound 3, half-maximal inhibitory concentration: 9 nM
Estimate against measurement, compound 3: 39-fold (1.59 log units) above; measured number outside the range, below it.
By their numbers in this assay, from the lowest: compound 3; then compounds 2 and 1 (each within the scatter of the next).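

In this assay, chain length at this place turns out to matter far more than the two earlier compounds suggested: the change from methyl to undecyl gives a 28-fold lower number from compound 2 to compound 3 (1.44 log units; beyond the scatter), and the change from tetradecyl to undecyl gives a 56-fold lower number from compound 1 to compound 3 (1.74 log units; beyond the scatter). The response to length is therefore not a steady slope, since the methyl and tetradecyl compounds cannot be told apart while the undecyl compound stands far from both, and a propyl piece at the end of the chain separates a large gain from none. Nothing at hand explains why this chain length stands out so sharply.

As far as these compounds go, it remains open where along the series the gain begins and how narrow it is, since a hexyl, an octyl or a dodecyl chain could show whether undecyl sits on a sharp peak or on a broader plateau. From the compounds shown here alone, it is also open whether the gain depends on an unbroken carbon chain, which an ether oxygen inside the chain or a carboxylic acid at its end would test.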